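The compounds below may be only part of what the source reports. "The series", "measured", "known", "first", "only" and "open" are said of these compounds alone.

Compound 1, with the structure `CCOC(=O)c1c(-c2cccc(OC)c2)[nH]c2cc(OC)ccc2c1=O`, was examined in an ADME assay on HEK293 cells (Homo sapiens) for cytotoxicity, read by luminescence, with a stated time of 72 h; on this read-out lower numbers stand for an effect already at smaller amounts and higher numbers for an effect only at larger amounts of compound. In this assay compound 1 gives > 22000 nM, and this is a limit of the assay, not a measured number. Compound 2, with the structure `CCOC(=O)c1c(-c2cccc(Oc3ccccc3)c2)[nH]c2cc(OC)ccc2c1=O`, was examined in the same way, and in this assay compound 2 gives > 22000 nM, which is likewise a limit of the assay. For the measured compounds named here, the only step between measured compounds, a step that the two limits leave unreadable from compound 1 to compound 2, cannot be read in size, because of the limit of > 22000 nM in this assay, at which 2 of the 2 values shown sit.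

Compound 3, with the structure `CCOC(=O)c1c(-c2cccc(C(F)(F)F)c2)[nH]c2cc(OC)ccc2c1=O`, has not yet been tested in this assay. It differs from compound 1 by trifluoromethyl in place of methoxy on an aromatic carbon. Going by the values given here, no measured step touches a trifluoromethyl group, and the one step that is known gives no readable size, so nothing among the measured compounds points to a change in either direction. Compound 3 is therefore expected to sit near compound 1, with the step that the limit leaves unreadable from compound 1 to compound 3 estimated as no change beyond the scatter. For compound 3 in this assay the estimate is 30000 nM, with a range from 10000 nM to 100000 nM, and most likely the assay will again report only a limit.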

Compound 3, half-maximal effective concentration: > 22000 nM
Compound 3: only a limit was reported (the forecaster's own chance of this, stated with the estimate: 80%); the middle value is on the limit's open side.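

No size can be read for the steps from compound 1 to compound 3 or from compound 2 to compound 3 in this assay, because all three compounds stop at the same limit of the assay: the limit of > 22000 nM in this assay, at which 3 of the 3 values shown sit.

The compounds shown leave open whether methoxy, phenoxy and trifluoromethyl on the shared core differ at all in this assay.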